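Working notes: dimethylamino for ethylamino on the carbonyl

The source may hold more compounds than are shown below. What is called first, only, known or untested is meant among the compounds shown, and "the series" means these compounds.

In an ADME assay on HeLa cells (Homo sapiens) for cytotoxicity, read by MTT assay, with a stated time of 2 days (a higher number here means that more compound is tolerated, a lower number that less compound is tolerated), compound 1 `CNC(=O)c1cc(Oc2ccc3c(C)c(C(=O)OC)sc3c2)ccn1` gives 15700 nM as a measured value. Compound 2 `CCNC(=O)c1sc2cc(Oc3ccnc(C(=O)NC)c3)ccc2c1C` gives > 100000 nM in the same read-out, and this is a limit of the assay, not a number. Its standing is therefore known only as a limit (the limit of > 100000 nM in this assay, at which 1 of the 2 values shown sits). For the measured compounds named here, the one measured step is ethylamino in place of methoxy on a carbonyl carbon (an at least 6.3-fold higher number from compound 1 to compound 2 (0.80 log units; beyond the scatter)).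

Compound 3 `CNC(=O)c1cc(Oc2ccc3c(C)c(C(=O)N(C)C)sc3c2)ccn1` carries dimethylamino in place of ethylamino on a carbonyl carbon. Going by the values given here, only that one step bears on this change, and it is not the same change. Compound 3 also lacks the methoxy of compound 1, so most of the rise seen for compound 2 (an at least 6.3-fold higher number from compound 1 to compound 2 (0.80 log units; beyond the scatter)) is expected to carry over. The expected step is small and toward a lower number (an at least 1.2-fold lower number from compound 2 to compound 3 (0.09 log units; that floor lies within the scatter)), and a repeat of the limit remains quite possible. For compound 3 the estimate is 80000 nM, with an expected range from 25000 nM to 200000 nM in this assay.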

Compound 3, half-maximal cytotoxic concentration: 44400 nM
Compound 3: the middle estimate sits 1.8-fold (0.26 log units) above what was measured, within the range that was stated.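

In this assay, the change at this carbonyl carbon now has a step with measured values at both ends, as dimethylamino in place of methoxy gives a 2.8-fold higher number from compound 1 to compound 3 (0.45 log units; beyond the scatter). The two amides also do not behave alike, even though ethylamino and dimethylamino have the same heavy-atom count and differ in that ethylamino carries a hydrogen-bond donor and dimethylamino none: the exchange gives an at least 2.2-fold lower number from compound 2 to compound 3 (0.35 log units; beyond the scatter). Going by these compounds, the full size of that step stays unknown, since compound 2 stands only as a limit of the assay: the limit of > 100000 nM in this assay, at which 1 of the 3 values shown sits.

The three compounds cannot separate the loss of the amide hydrogen from the different arrangement of the two carbons, so neither can be named as what matters at this position. Methylamino, diethylamino or a cyclic amine such as pyrrolidine on the same carbonyl carbon would bear on that question, and the carboxylic acid would show how far the tolerated concentration depends on having an ester or an amide here at all.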